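This account rests on a few compounds, and the source may have more. Where it says the series, first, only, none or still open, it means among the compounds named here.

The series is judged in a functional assay on PC-3 cells (Homo sapiens) for antiproliferative activity, read by MTT assay, with a stated time of 48 h; on this read-out higher numbers stand for weaker inhibition of growth and lower numbers for stronger inhibition of growth. Compound 1 `CCOc1cc(NC(=O)CCCCCCC(=O)Nc2ccccc2N)cc2c1OCC([N+](=O)[O-])=C2` gives 8630 nM, and compound 2 `CCOc1cc(NC(=O)CCCCCCC(=O)Nc2cc(-c3ccc(C)s3)ccc2N)cc2c1OCC([N+](=O)[O-])=C2` gives 6360 nM; the change that separates them, (hydrogen in place of 5-methylthiophen-2-yl on an aromatic carbon), made a 1.4-fold higher number from compound 2 to compound 1 (0.13 log units; within the scatter). Compound 3 `CCOc1cc(NC(=O)CCCCC(=O)Nc2cc(-c3ccc(C)s3)ccc2N)cc2c1OCC([N+](=O)[O-])=C2` gives 13500 nM, a higher number than compound 2 shows; the difference between the cores of compound 2 and compound 3 is not broken down here. Compound 4 `CCOc1cc(NC(=O)CCCCC(=O)Nc2ccccc2N)cc2c1OCC([N+](=O)[O-])=C2` has not been measured. It differs from compound 3 by hydrogen in place of 5-methylthiophen-2-yl on an aromatic carbon, the same change that was made from compound 2 to compound 1. A step of a 1.3-fold higher number from compound 3 to compound 4 (0.10 log units; within the scatter) is expected, because the earlier 1.4-fold higher number from compound 2 to compound 1 (0.13 log units; within the scatter) stayed within the scatter and compound 3 starts from 13500 nM. Compound 4 is therefore estimated at 17000 nM, with a likely range from 8000 nM to 40000 nM.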

Compound 4, concentration for 50% growth inhibition: 18900 nM
Compound 4: middle estimate off by 1.1-fold (0.05 log units), on the low side, within the range that was stated.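

In this assay, putting hydrogen in place of the 5-methylthiophen-2-yl group gave a 1.4-fold higher number from compound 3 to compound 4 (0.15 log units; within the scatter), and this step agrees with the one seen earlier on the other core: the same change on two cores in this assay, a 1.4-fold higher number (0.13 log units; within the scatter) from compound 2 to compound 1 and a 1.4-fold higher number (0.15 log units; within the scatter) from compound 3 to compound 4, 1.0-fold (0.01 log units) apart, within the scatter of two such steps

Across these two cores, then, the change carries over as a step that stays within the scatter. This does not show that the 5-methylthiophen-2-yl group truly alters growth inhibition, and two cores cannot establish a rule for the whole series.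

As far as these compounds go, it remains open whether a phenyl or furan-2-yl group at the same place would give a step beyond the scatter. From the compounds shown here alone, it is equally open whether this change would behave the same way on a core with a longer chain.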